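Dimethoxyphenyl for dimethylphenyl on a quinoline sulfone scaffold

A few compounds are considered here, and "the series" means these few. Any claim that something is new, unique, unknown or untested is made for them only; others in the source may bear on it.

Compound 1 `COc1ccc(S(=O)(=O)c2cnc3ccc(Cl)cc3c2N2CCC(C)CC2)cc1OC`: 61%
Compound 2 `COc1ccc2ncc(S(=O)(=O)c3cc(C)cc(C)c3)c(N3CCC(C)CC3)c2c1`: 79%
Compound 3 `Cc1cc(C)cc(S(=O)(=O)c2cnc3ccc(Cl)cc3c2N2CCC(C)CC2)c1`: 49%

In an assay on isolated protein for displacement of a labelled ligand from metabotropic glutamate receptor 5 (Homo sapiens), with a stated time of 60 min, tested at 1 uM (a higher number here means more inhibition at the concentration tested (going by the name of the read-out), a lower number less inhibition), compound 2 gives the highest of the three numbers, with compound 1 and compound 3 both beyond the scatter below it. Compound 3 and compound 1 differ by one change, (3,4-dimethoxyphenyl in place of 3,5-dimethylphenyl on a sulfonyl sulfur), and that change gave a number 12 percentage points higher from compound 3 to compound 1 (beyond the scatter). Compound 4 `COc1ccc2ncc(S(=O)(=O)c3ccc(OC)c(OC)c3)c(N3CCC(C)CC3)c2c1` is not yet measured; it arises from compound 2 by the same change, (3,4-dimethoxyphenyl in place of 3,5-dimethylphenyl on a sulfonyl sulfur). The cores of compound 2 and compound 3 differ in this way: methoxy in place of chloro on an aromatic carbon, with a number 30 percentage points lower from compound 2 to compound 3 (beyond the scatter). Because compound 3 to compound 1 showed a number 12 percentage points higher from compound 3 to compound 1 (beyond the scatter), a step of similar size upward is expected for compound 4, a number 8 percentage points higher from compound 2 to compound 4 (within the scatter), though the high starting value of compound 2 leaves less room. Compound 4 is therefore estimated at 87%, within 72% to 98%.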

Compound 4, a percentage reported as inhibition, at one concentration (the size of the read-out at that concentration, not a potency): -3%
Estimate against measurement, compound 4: 90 percentage points above, outside the stated range (below it).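

In this assay, 3,4-dimethoxyphenyl in place of 3,5-dimethylphenyl on a sulfonyl sulfur gave a number 82 percentage points lower from compound 2 to compound 4 (beyond the scatter), so this change did not carry over in size or direction from the other core: the same change on two cores in this assay, a number 12 percentage points higher (beyond the scatter) from compound 3 to compound 1 and a number 82 percentage points lower (beyond the scatter) from compound 2 to compound 4, 94 percentage points apart, beyond the scatter of two such steps. Methoxy in place of chloro on an aromatic carbon gave a number 64 percentage points lower from compound 1 to compound 4 (beyond the scatter), so that change also depends on the group on the sulfonyl sulfur: the same change on two cores in this assay, a number 30 percentage points lower (beyond the scatter) from compound 2 to compound 3 and a number 64 percentage points higher (beyond the scatter) from compound 4 to compound 1, 94 percentage points apart, beyond the scatter of two such steps. This shows that the two changes do not add up across these four compounds, but it does not show why, or which core would be the exception in a wider series.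

Going by these compounds, how either core would respond to another group on the sulfonyl sulfur, such as a phenyl carrying a single methoxy or a carboxylic acid, remains open. The compounds shown also leave open whether an amine in place of the methoxy or chloro would follow either pattern.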